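A few compounds are considered here, and "the series" means these few. Any claim that something is new, unique, unknown or untested is made for them only; others in the source may bear on it.

Measured compounds:
compound 1, `C=C1C2=C(C(=O)N1OC)[C@H](OC(=O)CSc1nc3ccccc3o1)[C@@](C)(O)[C@H](CCCCC)O2`: 5800 nM
compound 2, `C=C1C2=C(C(=O)N1OC)[C@H](O)[C@@](C)(O)[C@H](CCCCC)O2`: 32000 nM
compound 3, `C=C1C2=C(C(=O)N1OC)[C@H](OC(=O)CSc1nc3ccccc3[nH]1)[C@@](C)(O)[C@H](CCCCC)O2`: 6400 nM

In a functional assay on PC-3 cells (Homo sapiens) for cytotoxicity, read by MTT assay, with a stated time of 72 h (a lower number here means a stronger inhibitor, a higher number a weaker inhibitor), compound 2 gives the highest number of the three, and both compound 1 and compound 3 lie beyond the scatter from it. Compound 4, `C=C1C2=C(C(=O)N1OC)[C@H](OC(=O)CCl)[C@@](C)(O)[C@H](CCCCC)O2`, differs from compound 2 by (chloromethyl)carbonyl in place of hydrogen on an oxygen on a saturated carbon. For the measured compounds named here, no measured step makes exactly this change; the one measured step, a 1.1-fold higher number from compound 1 to compound 3 (0.04 log units; within the scatter), concerns the far end of an ester and not its presence. The gap between compound 2 and the two esters is the comparison that bears on the case, and on that ground the step from compound 2 to compound 4 is expected to lower the number beyond the scatter, a 3.6-fold lower number from compound 2 to compound 4 (0.55 log units; beyond the scatter). Compound 4 is therefore estimated at 9000 nM, with a range from 3000 nM to 30000 nM.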

Compound 4, half-maximal inhibitory concentration: 2400 nM
Beside the measured number, compound 4's estimate is 3.8-fold (0.57 log units) above it; measured number below the stated range.
By their numbers in this assay, from the lowest: compound 4; then compounds 1 and 3 (each within the scatter of the next); then compound 2.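

In this assay, the hydroxy to ((chloromethyl)carbonyl)oxy change on this saturated carbon gives a large gain, a 13-fold lower number from compound 2 to compound 4 (1.12 log units; beyond the scatter), and compound 4 has the lowest number of the four. The far end of the ester therefore matters here: chloro in place of the sulfanyl groups gives a 2.7-fold lower number from compound 3 to compound 4 (0.43 log units; beyond the scatter) and a 2.4-fold lower number from compound 1 to compound 4 (0.38 log units; beyond the scatter), both modest but beyond the scatter. No measurement shown explains this gain. The compounds shown leave open how a plain acetyl ester, or an amine in place of chloro on that chain carbon, would compare.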